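Methyl for amino in the pyrimidine-core propargyl ether series

The source may report more compounds than this note shows. Statements on the series, on what has been measured and on what is new or still open speak of the compounds shown alone.

Compound 1 `C#CCOc1ccc(-c2cc(-c3ccc(OCC#C)cc3)nc(C)n2)cc1`: 7830 nM
Compound 2 `C#CCOc1ccc(-c2cc(-c3ccc(OCC#C)c(OC)c3)nc(N)n2)cc1`: 20000 nM

In an assay on BTI-TN-5B1-4 cells for inhibition of Amine oxidase [flavin-containing] B (Homo sapiens), read by fluorescence and Amplex Red, using microsomes, with a stated time of 30 min (a higher number here means a weaker inhibitor, a lower number a stronger inhibitor), compound 2 gives the higher of the two numbers; compound 1 sits at a lower number, and that gap is beyond the scatter. The two compounds differ in two places, so no single step can be read from them.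

Compound 3 `C#CCOc1ccc(-c2cc(-c3ccc(OCC#C)c(OC)c3)nc(C)n2)cc1` carries methyl in place of amino on an aromatic carbon, that is methyl in place of amino on an aromatic carbon. The expected step is a 2.0-fold lower number from compound 2 to compound 3 (0.30 log units; within the scatter), downward, because compound 1 with the same methyl gives 7830 nM in this assay. Compound 3 is estimated at 10000 nM, with a range of 4000 nM to 25000 nM.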

Compound 3, half-maximal inhibitory concentration: 21100 nM
Compound 3: middle estimate off by 2.1-fold (0.32 log units), on the low side, within the range that was stated.
By their numbers in this assay, from the lowest: compound 1; then compounds 2 and 3 (each within the scatter of the next).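

In this assay, methyl in place of amino on an aromatic carbon between two ring nitrogen atoms gives a 1.1-fold higher number from compound 2 to compound 3 (0.02 log units; within the scatter) and so shows no readable effect at this position while the methoxy is present. The step that does register is methoxy in place of hydrogen on an aromatic carbon, with a 2.7-fold higher number from compound 1 to compound 3 (0.43 log units; beyond the scatter) as a modest change beyond the scatter. Open, from the compounds shown here alone, are whether an ethyl or a dimethylamino group at this position would move the number and whether the methyl-for-amino step holds without the methoxy. Nothing available bears on the reason for either step.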